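A few compounds are considered here, and "the series" means these few. Any claim that something is new, unique, unknown or untested is made for them only; others in the source may bear on it.

The study follows cytotoxicity in an ADME assay on HepG2 cells (Homo sapiens) for cytotoxicity, in the presence of a further agent that is not named here (a higher number here means a weaker inhibitor, a lower number a stronger inhibitor), across a small set of compounds that share one core. Compound 1 `COc1nc(C(C)c2ccccc2C(F)(F)F)nc(C(=O)NCc2ccccc2)c1O` returns only a limit of the assay: in this assay compound 1 gives > 100000 nM. Compound 3 `Cn1c(Cc2ccccc2)nc(C(=O)NCc2ccccc2)c(O)c1=O` returns a limit as well, and in this assay compound 3 shows > 100000 nM. Compound 2 `Cn1c(Cc2ccccc2C(F)(F)F)nc(C(=O)CCc2ccccc2)c(O)c1=O` stands in the same place: in this assay compound 2 gives > 100000 nM, which is a limit and not a number. Where compound 2 stands is therefore the ceiling of what the assay reports, the same point described by the limit of > 100000 nM in this assay, at which 3 of the 3 values shown sit.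

Compound 4 `Cn1c(Cc2ccccc2C(F)(F)F)nc(C(=O)NCc2ccccc2F)c(O)c1=O` differs from compound 2 in a single place: (2-fluorobenzyl)amino in place of phenethyl on a carbonyl carbon. Going by the values given here, no step between two measured compounds is available, so the change has no measured precedent of its own. Every value shown sits at the limit of > 100000 nM in this assay, at which 3 of the 3 values shown sit, and on that basis no step beyond the usual scatter of this assay is expected in either direction; the expected step is a number no higher from compound 2 to compound 4 (the limit leaves the size open). Compound 4 is estimated in this assay at 100000 nM, with a range from 40000 nM to 300000 nM, and the most likely outcome is that the assay again reports only a limit for compound 4.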

Compound 4, half-maximal inhibitory concentration: > 100000 nM
Compound 4: no number, only a limit; the forecaster's own chance of this, stated with the estimate: 85%; the middle value sits exactly at the limit.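

In this assay compound 4 gives > 100000 nM, which is a limit and not a number. Compound 2 also returns only a limit, so no step can be read between compound 2 and compound 4. The compounds shown leave open what any of them would measure as a number, and so whether (2-fluorobenzyl)amino in place of phenethyl on a carbonyl carbon changes the read-out at all.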